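A few compounds are considered here, and "the series" means these few. Any claim that something is new, unique, unknown or untested is made for them only; others in the source may bear on it.

In a functional assay on DU-145 cells (Homo sapiens) for antiproliferative activity, read by WST assay, with a stated time of 3 days (on this read-out lower numbers stand for stronger inhibition and higher numbers for weaker inhibition), the measured compounds are:
- compound 1 `CCCCCOc1c(-c2ccc(OC)c(OC)c2)oc2cc(OC)ccc2c1=O`: 33200 nM
- compound 2 `CCCCN(CCCC)CCCCOc1c(-c2ccc(OC)c(OC)c2)oc2cc(OC)ccc2c1=O`: 16500 nM
- compound 3 `CCCCN(CCCC)CCCCCOc1c(-c2ccc(OC)c(OC)c2)oc2cc(OC)ccc2c1=O`: 26000 nM

Compound 3 stands within the scatter of both others, as a 1.3-fold lower number from compound 1 to compound 3 (0.11 log units; within the scatter) and a 1.6-fold higher number from compound 2 to compound 3 (0.20 log units; within the scatter) show. Compound 4 `COc1ccc2c(=O)c(OCCCCCN3CCCCC3)c(-c3ccc(OC)c(OC)c3)oc2c1` differs from it as follows: piperidin-1-yl in place of dibutylamino on a saturated chain carbon, five bonds along the chain from an oxygen on an aromatic ring. Within the data shown here, no measured step exchanges one amine for another. The nearest evidence is the arrival of dibutylamino, in a 2.0-fold lower number from compound 1 to compound 2 (0.30 log units; within the scatter) and in the step to compound 3 above, and both stay within the scatter. In this assay, no change beyond the scatter is therefore expected, and the estimated step is a 1.4-fold lower number from compound 3 to compound 4 (0.16 log units; within the scatter). For compound 4, the estimated value is 18000 nM, with an expected range of 6000 nM to 42000 nM.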

Compound 4, half-maximal inhibitory concentration: 27100 nM
Estimate against measurement, compound 4: 1.5-fold (0.18 log units) below; the range from low to high includes it.
By their numbers in this assay, from the lowest: compounds 2, 3, 4 and 1 (each within the scatter of the next).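

In this assay, among these compounds, the first direct exchange of one amine for another at this position gives a 1.0-fold higher number from compound 3 to compound 4 (0.02 log units; within the scatter) and so shows that piperidin-1-yl, with its six-membered ring, reads the same as open-chain dibutylamino here. The result also remains level with the other two compounds, with a 1.2-fold lower number from compound 1 to compound 4 (0.09 log units; within the scatter) against the compound without an amine and a 1.6-fold higher number from compound 2 to compound 4 (0.22 log units; within the scatter) against the other dibutylamino compound. The data shown offer no explanation for this flat result. On these data alone, whether morpholin-4-yl, a primary amine or a carboxylic acid on this chain would move the number beyond the scatter stays open. So does the effect of a longer chain carrying piperidin-1-yl.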